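From tert-butyl to benzyl on the shared core

A few compounds are considered here, and "the series" means these few. Any claim that something is new, unique, unknown or untested is made for them only; others in the source may bear on it.

In a functional assay (muscle tissue) with Felis catus as the target (a higher number here means that more compound is needed for the effect, a lower number that less compound is needed), compound 1 `CCc1nc(O)c(C#N)c(NCc2cccnc2)n1` carries ethyl and reads 5500 nM as its value. Compound 2 `CC(C)c1nc(O)c(C#N)c(NCc2cccnc2)n1` carries isopropyl and reads 33000 nM while compound 3 `CC(C)(C)c1nc(O)c(C#N)c(NCc2cccnc2)n1` carries tert-butyl and reads 55000 nM on the same scale. Compound 3 therefore sits with compound 2 at the high end of these numbers, the pair lying within the scatter of each other and well clear of compound 1. Compound 4 `N#Cc1c(O)nc(Cc2ccccc2)nc1NCc1cccnc1` has benzyl in place of tert-butyl on an aromatic carbon and is otherwise the same. Within the data shown here, three measured steps bear on this place. Adding one methyl to the ethyl gave a 6.0-fold higher number from compound 1 to compound 2 (0.78 log units; beyond the scatter) and the next methyl gave a 1.7-fold higher number from compound 2 to compound 3 (0.22 log units; within the scatter) with only the first beyond the scatter. Together they amount to a 10-fold higher number from compound 1 to compound 3 (1.00 log units; beyond the scatter) across the series. Benzyl, like ethyl, has no branch on the carbon bound to the aromatic carbon, so part of that gap is expected to close. Among the measured compounds shown here, no measured compound has a ring in this place, which leaves the expectation loose. The estimated step is a 3.7-fold lower number from compound 3 to compound 4 (0.56 log units; beyond the scatter) toward a lower number. For compound 4 the expected value is 15000 nM with an estimated range from 3500 nM to 60000 nM in this assay.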

Compound 4, half-maximal effective concentration: 72000 nM
Compound 4: the middle estimate sits 4.8-fold (0.68 log units) below what was measured, outside the stated range (above it).
By their numbers in this assay, from the lowest: compound 1; then compounds 2, 3 and 4 (each within the scatter of the next, the first and the last beyond it).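

Replacing ethyl with benzyl on this aromatic carbon gives a 13-fold higher number from compound 1 to compound 4 (1.12 log units; beyond the scatter) in this assay and shows that, among these compounds, having no branch on the carbon bound to the aromatic carbon does not by itself keep the number low. Benzyl instead gives a 1.3-fold higher number from compound 3 to compound 4 (0.12 log units; within the scatter) and a 2.2-fold higher number from compound 2 to compound 4 (0.34 log units; beyond the scatter), which places compound 4 with compound 3 at the high end, well clear of compound 1. No supporting measurement is available to explain this result.

The compounds shown leave open whether a longer straight chain such as propyl would read closer to ethyl or to benzyl, and whether methyl would give a lower number than ethyl. Also open, as far as these compounds go, is how an amine at this place would read.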